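A few compounds are considered here, and "the series" means these few. Any claim that something is new, unique, unknown or untested is made for them only; others in the source may bear on it.

Measured compounds:
compound 1 `CC(C)=CCC[C@]1(C)/C=C/[C@@H](OC(=O)C=C(C)C)[C@](C)(O)/C=C/C(=O)/C(C(=O)O)=C\C1` – in a functional assay on SMMC-7721 cells (Homo sapiens) for antiproliferative activity, read by MTT assay, with a stated time of 48 h (on this read-out higher numbers stand for weaker inhibition and lower numbers for stronger inhibition), compound 1 gives > 10000 nM; this is a limit of the assay, not a number.
compound 2 `CCN(CC)C/C1=C/C[C@](C)(CCC=C(C)C)/C=C/[C@@H](OC(=O)C=C(C)C)[C@](C)(O)/C=C/C1=O` – in this assay compound 2 gives 570 nM.
compound 3 `CC[Si](CC)(CC)C/C1=C/C[C@](C)(CCC=C(C)C)/C=C/[C@@H](OC(=O)C=C(C)C)[C@](C)(O)/C=C/C1=O` – in this assay compound 3 gives 3460 nM.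

Compound 3 stands with the highest of the two numbers shown; its nearest neighbour is compound 2, with a 6.1-fold higher number from compound 2 to compound 3 (0.78 log units; beyond the scatter). Going by the values given here, the only other value, that of compound 1, is a limit (the limit of > 10000 nM in this assay, at which 1 of the 3 values shown sits).

Compound 4 `CC(C)=CCC[C@]1(C)/C=C/[C@@H](OC(=O)C=C(C)C)[C@](C)(O)/C=C/C(=O)/C(C(=O)N(C(C)C)C(C)C)=C\C1` differs from compound 3 in one place: a group of 9 heavy atoms (7 carbon, 1 nitrogen, 1 oxygen; no ring) in place of a group of 8 heavy atoms (7 carbon, 1 silicon; no ring), on a double-bonded ring carbon. The entering group shares its carbonyl with the carboxy of compound 1, whereas the leaving group is the silicon-bearing chain that gave an at least 2.8-fold lower number from compound 1 to compound 3 (0.46 log units; beyond the scatter). Both measured steps away from the carboxy of compound 1, an at least 17-fold lower number from compound 1 to compound 2 (1.24 log units; beyond the scatter) and an at least 2.8-fold lower number from compound 1 to compound 3 (0.46 log units; beyond the scatter), lowered the number, so a return toward a carbonyl-bearing substituent is expected to move back in the other direction, though an amide is not the acid itself and the size is uncertain. A modest rise beyond the scatter is expected for compound 4, a 2.0-fold higher number from compound 3 to compound 4 (0.31 log units; beyond the scatter), with a real chance that only a limit is reported.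

For compound 4 the estimate is 7000 nM, within 1500 nM to 25000 nM.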

Compound 4, half-maximal inhibitory concentration: 17200 nM
The estimate for compound 4 lay 2.5-fold (0.39 log units) below the measured number; measured number inside the range.
By their numbers in this assay, from the lowest: compound 2; then compound 3; then compound 4.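

In this assay, a carbonyl-bearing substituent on this double-bonded ring carbon now has a readable number, and it sits at the weak end of the exact values: a 5.0-fold higher number from compound 3 to compound 4 (0.70 log units; beyond the scatter), and a 30-fold higher number from compound 2 to compound 4 (1.48 log units; beyond the scatter). The groups exchanged between compound 3 and compound 4 are close in heavy-atom count, yet the number moves beyond the scatter, so among these compounds heavy-atom count alone does not order the substituents at this position. Compound 1 carries a limit, so the change from its hydroxy to diisopropylamino on the carbonyl carbon, the step to compound 4, cannot be read: the limit of > 10000 nM in this assay, at which 1 of the 4 values shown sits.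

As far as these compounds go, the step between compound 2 and compound 4 changes both the carbonyl and the groups on nitrogen, so the share of each remains open; a diethylcarbamoyl group or a (diisopropylamino)methyl group would separate them. Also open, from the compounds shown here alone, is whether a methyl ester or an unsubstituted carboxamide at this position would give a number closer to that of compound 2 or to that of compound 4.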